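The compounds below may be only part of what the source reports. "The series", "measured", "known", "first", "only" and "open" are said of these compounds alone.

Measured compounds in the series:

compound 1, `CO[C@H]1CC=C2CCN(C)[C@H]2C1`
compound 2, `CN1CC[C@@H]2CC[C@H](O)C[C@@H]21`
compound 3, `O[C@H]1CC[C@H]2CCN[C@H]2C1`

Within the data shown here, in an assay on HEK293 cells for displacement of a labelled ligand from Neuronal acetylcholine receptor; alpha4/beta4 (Rattus norvegicus), with a stated time of 4 h (on this read-out higher numbers stand for weaker inhibition and lower numbers for stronger inhibition), compound 1 gives 100000 nM, the only number in the set. Compound 2 reaches only a limit of this assay, > 300000 nM. Compound 3 likewise ends at a limit, > 300000 nM. Among the measured compounds shown here, two of the three values therefore sit at the limit of > 300000 nM in this assay, at which 2 of the 3 values shown sit, and the one number stands well into the weak range.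

The step from compound 2 to compound 3 is hydrogen in place of methyl on an amine nitrogen in a ring. Its size is a step that the two limits leave unreadable from compound 2 to compound 3; the two limits give no reading. The difference between the core of compound 1 and the core of compound 2 is not broken down here.

Compound 4, `CO[C@H]1CC=C2CCN[C@H]2C1`, is not yet measured in this assay. It is made from compound 1 by hydrogen in place of methyl on an amine nitrogen in a ring. For the measured compounds named here, this is the same kind of change as the one from compound 2 to compound 3, but the place differs: in compound 4 it sits next to the ring atom that bears a fused ring, while in compound 3 it sits next to the ring atom that bears a fused ring and two ring bonds from the ring atom that bears a fused ring. The measured instance of this change left its size unreadable, so the expectation for compound 4 can rest only on the weak value of compound 1, 100000 nM, and on what compound 2 and compound 3 show. Compound 2 and compound 3, the two compounds lacking the methyl, both end at a limit of this assay. The step from compound 1 to compound 4 is expected to be about a 1.6-fold higher number from compound 1 to compound 4 (0.20 log units; within the scatter). For compound 4 the estimate in this assay is 160000 nM, from 50000 nM to 500000 nM, with a real chance that only a limit is returned.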

Compound 4, inhibition constant: > 300000 nM
Compound 4: only a limit was reported (the forecaster's own chance of this, stated with the estimate: 45%); at least 1.8-fold (0.27 log units) between middle value and limit.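

In this assay, putting hydrogen in place of methyl on an amine nitrogen in a ring of the core of compound 1 gives an at least 3.0-fold higher number from compound 1 to compound 4 (0.47 log units; beyond the scatter), so on this core the change lies beyond the scatter and weakens the read-out, though only a minimum size is known. The same change on the core of compound 2 gives a step that cannot be read, so these data neither confirm nor contradict that the effect carries from one core to the other. No size can be compared between the two cores, and even the step on the core of compound 1 has no upper bound, because the values end at a limit: the limit of > 300000 nM in this assay, at which 3 of the 4 values shown sit.

Among these compounds, compound 1 is the only compound with a number, 100000 nM, so the series offers a single fixed point and no measured gain from any change. On these data alone, it remains open whether a longer chain such as ethyl, or a benzyl group, on the ring nitrogen would move the value in either direction, and whether an amine or a carboxylic acid in place of the methoxy group of compound 1 would bring a readable change.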